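Working notes: one benzyl swap carried onto a second core

The source may hold more compounds than are shown below. What is called first, only, known or untested is meant among the compounds shown, and "the series" means these compounds.

Compound 1 `COc1cc(OC)c(/C=C(/SCc2ccc(Cl)cc2Cl)C(=O)c2ccc(Cl)cc2)c(OC)c1` is the reference point of this set. In a functional assay on DU-145 cells (Homo sapiens) for inhibition, read by trypan blue exclusion, with a stated time of 96 h (on this read-out higher numbers stand for weaker inhibition of growth and lower numbers for stronger inhibition of growth), compound 1 gives 1000 nM. Compound 2 `COc1cc(OC)c(/C=C(/SCc2ccc(F)cc2)C(=O)c2ccc(Cl)cc2)c(OC)c1` differs from compound 1 only at the group on the saturated chain carbon bound to a sulfur; the difference is 4-fluorophenyl in place of 2,4-dichlorophenyl on a saturated chain carbon bound to a sulfur. In this assay compound 2 gives 10000 nM, and the step is a 10-fold higher number from compound 1 to compound 2 (1.00 log units; beyond the scatter).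

Compound 3 `CN(C)c1ccc(/C=C(/SCc2ccc(Cl)cc2Cl)C(=O)c2ccc(Cl)cc2)cc1` sits on a different core; the difference between the core of compound 3 and the core of compound 1 is not broken down here. In this assay compound 3 gives 50000 nM, the highest number of the three measured compounds, beyond the scatter from both compound 2 and compound 1.

Compound 4 `CN(C)c1ccc(/C=C(/SCc2ccc(F)cc2)C(=O)c2ccc(Cl)cc2)cc1` has not been measured. It stands to compound 3 as compound 2 stands to compound 1: the change is 4-fluorophenyl in place of 2,4-dichlorophenyl on a saturated chain carbon bound to a sulfur. The place is worded identically in both pairs, so this is the same change and not merely the same kind. Going by the values given here, the step expected in this assay is a 6.0-fold higher number from compound 3 to compound 4 (0.78 log units; beyond the scatter), set beside the earlier measured step, because a 10-fold higher number from compound 1 to compound 2 (1.00 log units; beyond the scatter) is the only measured instance of this change and it moved the number upward. The estimate rests on a single pair and on a starting point for compound 3 of 50000 nM, which is already the highest number of the three measured compounds, so the range for compound 4 is kept wide.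

Compound 4 is expected to give about 300000 nM in this assay, with an estimated range from 80000 nM to 1500000 nM.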

Compound 4, concentration for 50% growth inhibition: 50000 nM
Compound 4: middle estimate off by 6.0-fold (0.78 log units), on the high side, and the stated range ends above it.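

In this assay, 4-fluorophenyl in place of 2,4-dichlorophenyl on a saturated chain carbon bound to a sulfur gives no change at the digits printed from compound 3 to compound 4 (within the scatter), so the change that raised the number on the core of compound 1 leaves no readable step on the core of compound 3. The size of this step therefore does not carry from one core to the other in this series, and the two steps differ by more than the scatter: the same change on two cores in this assay, a 10-fold higher number (1.00 log units; beyond the scatter) from compound 1 to compound 2 and no change at the digits printed (within the scatter) from compound 3 to compound 4, 10-fold (1.00 log units) apart, beyond the scatter of two such steps. Going by these compounds alone, with only two pairs, this shows that the step depends on the core, but it does not show which feature of the two cores separates the steps, or what size the step would take on any third core.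

The compounds shown leave open whether the drop on the core of compound 1 follows from the loss of one chlorine or both, and a 4-chlorophenyl at the same place on each core would separate these two readings. Also open, from the compounds shown here alone, is how the two cores respond when the saturated chain carbon bound to a sulfur carries an unsubstituted phenyl, a longer chain or a carboxylic acid.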